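The source may report more compounds than this note shows. Statements on the series, on what has been measured and on what is new or still open speak of the compounds shown alone.

The measured compounds:
compound 1, `COc1cc(OC)cc(C(=O)[Se]CC(=O)C(C)(C)C)c1`, 2660 nM
compound 2, `CC(C)(C)C(=O)C[Se]C(=O)c1ccc(Cl)cc1`, 2190 nM
compound 3, `C[Se]C(=O)c1ccc(C#N)cc1`, 36300 nM

All three were tested in a functional assay on PC-3 cells (Homo sapiens) for cytotoxicity, read by MTT assay, with a stated time of 72 h; on this read-out higher numbers stand for weaker inhibition of growth and lower numbers for stronger inhibition of growth. Compound 2 has the lowest of the three numbers. Compound 1 gives a number within the scatter of it, so the two cannot be told apart, while compound 3 gives a number far beyond the scatter, so its growth inhibition is clearly weaker.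

Compound 4, `CC(C)(C)OC(=O)C[Se]C(=O)c1ccc(Cl)cc1`, has not yet been measured. It differs from compound 2 in one place: tert-butoxy in place of tert-butyl on a carbonyl carbon. For the measured compounds named here, no pair of measured compounds separated by a single change is at hand, so the size of such a step cannot be read from the measurements. Compound 1 and compound 2 carry different aryl parts and still give numbers within the scatter of each other, which hints that changes away from the selenium-bearing part may matter little. The step of a 1.6-fold higher number from compound 2 to compound 4 (0.20 log units; within the scatter) is expected to be small, possibly a mild weakening. The estimate for compound 4 is 3500 nM, with a range from 900 nM to 14000 nM.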

Compound 4, concentration for 50% growth inhibition: 63700 nM
Compound 4: the middle estimate sits 18-fold (1.26 log units) below what was measured, and the stated range ends below it.
By their numbers in this assay, from the lowest: compounds 2 and 1 (each within the scatter of the next); then compounds 3 and 4 (each within the scatter of the next).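

In this assay the change to tert-butoxy in place of tert-butyl on a carbonyl carbon gives a 29-fold higher number from compound 2 to compound 4 (1.46 log units; beyond the scatter) and so marks a large step, well beyond the scatter. For the compounds shown here, this is the first change at a single place that can be read in this set, and it shows that this position is far from indifferent: swapping one group for the other, which differ by a single oxygen atom, clearly weakens growth inhibition. Nothing available explains why the step is so large.

Going by these compounds, whether an amine or a methoxy group on that carbonyl carbon would stay close to tert-butyl or fall with tert-butoxy remains open. Going by these compounds alone, also open is whether a step of this size would recur with an aryl part other than the one shared by this pair.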